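Removing a methyl from a pyrrolidine diol near the floor of the read-out

This account rests on a few compounds, and the source may have more. Where it says the series, first, only, none or still open, it means among the compounds named here.

Measured so far:
- compound 1, `Cc1ccc([C@@H]2NC[C@H](O)[C@H]2O)cc1`: 0.4%
- compound 2, `Cc1ccc([C@H]2NC[C@@H](O)[C@@H]2O)cc1`: 0%

Both compounds were tested in an assay on isolated protein for inhibition of alpha-mannosidase (Canavalia ensiformis), read by spectrophotometry, tested at 1000 uM; on this read-out lower numbers stand for less inhibition and higher numbers for more inhibition at the one concentration tested (going by the name of the read-out). Compound 1 gives 0.4% and compound 2 gives 0%; compound 2 stands at the lower of the two numbers, but the difference a number 0.4 percentage points lower from compound 1 to compound 2 (within the scatter) is within the scatter, so the two read as alike. The two compounds share every atom and bond and are mirror images of each other (the fact that compounds 1 and 2 differ only in the configuration as drawn), and neither shows inhibition worth noting.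

Compound 3, `O[C@H]1[C@H](O)CN[C@@H]1c1ccccc1`, differs from compound 2 in one place: hydrogen in place of methyl on an aromatic carbon. Within the data shown here, no measured step involves this kind of change; the only step in hand, a number 0.4 percentage points lower from compound 1 to compound 2 (within the scatter), concerns configuration, not the methyl, and offers no guide to its removal. What the two measured compounds do show is that the shared core, with or without inversion, sits near the floor of the read-out. Compound 3 is therefore expected to stay there as well, with an expected step of a number 1 percentage points higher from compound 2 to compound 3 (within the scatter) of no size beyond the scatter. The estimate for compound 3 is 1%, in a range from 0% to 10%.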

Compound 3, a percentage reported as inhibition, at one concentration (the size of the read-out at that concentration, not a potency): 8.3%
The estimate for compound 3 lay 7.3 percentage points below the measured number, within the range that was stated.
By their numbers in this assay, from the lowest: compounds 2, 1 and 3 (each within the scatter of the next).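

Among these compounds, replacing the methyl with hydrogen on the aromatic ring is the first change at this position that can be read, and in this assay it gives a number 8.3 percentage points higher from compound 2 to compound 3 (within the scatter). This step lies within the scatter, so at the one concentration tested the methyl and the hydrogen read as alike on this shared core, and this position has not yet been shown to matter for the read-out. Nothing in hand offers an explanation for this step, as the one known fact about these compounds concerns their configuration and not this group.

A swap between methyl and hydrogen says little about how a methoxy group, a chlorine atom, an amine or a carboxylic acid would read at this same place on the aromatic ring. Also open, from the compounds shown here alone, are whether the mirror image of compound 3 would read like compound 3, as compound 1 and compound 2 read alike, and whether any change to this shared core can lift inhibition clearly beyond the scatter in this assay.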